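The compounds below may be only part of what the source reports. "The series", "measured", "known", "first", "only" and "open" are said of these compounds alone.

Working notes on the series. Compound 1 `Cc1n[nH]c2ccc(-c3nc4cnc(N5CCN(C)CC5)cn4c3Nc3ccccc3)cc12` carries a plain phenyl on the nitrogen on an aromatic ring; in a functional assay on MV4-11 cells (Homo sapiens) for inhibition, with a stated time of 120 h, tested at 10 uM (a higher number here means more inhibition at the concentration tested (going by the name of the read-out), a lower number less inhibition), compound 1 gives 0%. Compound 2 `Cc1cc(Br)ccc1Nc1c(-c2ccc3[nH]nc(C)c3c2)nc2cnc(N3CCN(C)CC3)cn12` carries 4-bromo-2-methylphenyl at that nitrogen, and in this assay compound 2 gives 59.4%. Within the data shown here, compound 2 stands highest of the two numbers in hand, its nearest neighbour being compound 1, and the only measured step is a number 59.4 percentage points higher from compound 1 to compound 2 (beyond the scatter).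

Compound 3 `Cc1n[nH]c2ccc(-c3nc4cnc(N5CCN(C)CC5)cn4c3Nc3ccc(F)cc3Br)cc12` has not yet been measured. Against compound 2 it differs by 2-bromo-4-fluorophenyl in place of 4-bromo-2-methylphenyl on a nitrogen on an aromatic ring. Among the measured compounds shown here, only the step from compound 1 to compound 2 bears on this; it shows that the substitution pattern of this phenyl can move the read-out by a large amount. Compound 3 keeps a substituted phenyl, so a full return to the level of compound 1 is not expected, but a drop beyond the scatter is plausible given the rearranged substituents. Compound 3 is expected at 40%, with a range from 10% to 70%. The estimated step is a number 19.4 percentage points lower from compound 2 to compound 3 (beyond the scatter).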

Compound 3, a percentage reported as inhibition, at one concentration (the size of the read-out at that concentration, not a potency): 82.4%
Estimate against measurement, compound 3: 42.4 percentage points below, outside the stated range (above it).
By their numbers in this assay, from the lowest: compound 1; then compound 2; then compound 3.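

The change from 4-bromo-2-methylphenyl to 2-bromo-4-fluorophenyl in this assay gives a number 23 percentage points higher from compound 2 to compound 3 (beyond the scatter), so the level reached with the first substituted phenyl is not the limit at this nitrogen. Against the plain phenyl, the same group gives a number 82.4 percentage points higher from compound 1 to compound 3 (beyond the scatter), which places compound 3 highest of the three and shows two different substitution patterns both lying clear of the unsubstituted case. No measurement in hand explains the rise from one substituted phenyl to the other.

The exchange alters the ring's substituents together, so the separate contributions of the bromine, the fluorine and the lost methyl stay unresolved. Also open, from the compounds shown here alone, is how a phenyl carrying a methoxy group, or a pyridine ring in place of the phenyl, would read at this nitrogen.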